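Anilide variation on a thiazolidinedione-bearing naphthalene core

This account rests on a few compounds, and the source may have more. Where it says the series, first, only, none or still open, it means among the compounds named here.

Measured compounds:
compound 1, `O=C(COc1ccc2cc(/C=C3/SC(=O)NC3=O)ccc2c1)Nc1cccc(F)n1`: 7200 nM
compound 2, `O=C(COc1ccc2cc(/C=C3/SC(=O)NC3=O)ccc2c1)Nc1ccccc1`: 4500 nM
compound 3, `O=C(COc1ccc2cc(/C=C3/SC(=O)NC3=O)ccc2c1)Nc1ccc(F)cc1`: 6600 nM

All three compounds share one core and differ only in the aryl group on the amide-type nitrogen. In an assay on isolated protein for inhibition of histone deacetylase 8 (Homo sapiens), with a stated time of 1 h (on this read-out higher numbers stand for weaker inhibition and lower numbers for stronger inhibition), compound 1 gives 7200 nM, compound 2 gives 4500 nM and compound 3 gives 6600 nM. The three numbers lie close together: the step of a 1.6-fold lower number from compound 1 to compound 2 (0.20 log units; within the scatter), the step of a 1.1-fold lower number from compound 1 to compound 3 (0.04 log units; within the scatter) and the step of a 1.5-fold higher number from compound 2 to compound 3 (0.17 log units; within the scatter) are each within the scatter, so compound 3 cannot be told apart from either of its neighbours on these numbers.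

Compound 4, `O=C(COc1ccc2cc(/C=C3/SC(=O)NC3=O)ccc2c1)Nc1c(F)cc(F)cc1Br`, is not yet measured. It differs from compound 3 in one place: 2-bromo-4,6-difluorophenyl in place of 4-fluorophenyl on an amide-type nitrogen. Among the compounds with values here, the only measured step that touches this kind of change is the step of a 1.5-fold higher number from compound 2 to compound 3 (0.17 log units; within the scatter), a fluoro in place of hydrogen on the same ring, and it stayed within the scatter. Within the data shown here, no measured step covers a bromo substituent or a second fluoro, so the bearing of those additions is unknown.

On that basis compound 4 is expected to give a number close to compound 3, with the step of a 1.1-fold lower number from compound 3 to compound 4 (0.04 log units; within the scatter) estimated to stay within the scatter. The estimate for compound 4 in this assay is 6000 nM, with a range from 2500 nM to 15000 nM.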

Compound 4, half-maximal inhibitory concentration: > 50000 nM
Compound 4: no number, only a limit; the forecaster's own chance of this, stated with the estimate: 10%; middle value at least 8.3-fold (0.92 log units) away from the limit.
By their numbers in this assay, from the lowest: compounds 2, 3 and 1 (each within the scatter of the next). At a limit, above all of these: compound 4.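

In this assay compound 4 gives no number, only a limit: the limit of > 50000 nM in this assay, at which 1 of the 4 values shown sits.

Even so, 2-bromo-4,6-difluorophenyl on the amide-type nitrogen moves the read-out beyond the scatter from each of the three earlier compounds, giving an at least 7.5-fold higher number from compound 3 to compound 4 (0.87 log units; beyond the scatter), an at least 11-fold higher number from compound 2 to compound 4 (1.04 log units; beyond the scatter) and an at least 6.9-fold higher number from compound 1 to compound 4 (0.84 log units; beyond the scatter). The earlier compounds shown here, whose phenyl, 4-fluorophenyl and 6-fluoropyridin-2-yl groups could not be told apart, made this position look indifferent to the aryl group it carries, whereas compound 4 shows that a change here can weaken inhibition well beyond the scatter, by an amount that the limit leaves without an upper end.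

Compound 4 brings in a bromo and a second fluoro together, so the compounds shown do not tell whether the bromo alone, the second fluoro alone or only the two together account for the loss. On these data alone, how a methyl, a methoxy or an amine on this aryl ring would read, and whether any group here would give stronger inhibition than the phenyl of compound 2, also stays open.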